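A few compounds are considered here, and "the series" means these few. Any claim that something is new, unique, unknown or untested is made for them only; others in the source may bear on it.

Measured so far:
compound 1, `CN(C)c1ncnc2c1c(-c1ccsc1)cn2[C@@H]1O[C@H](CO)[C@@H](O)[C@H]1O`: in a functional assay on A549 cells (Homo sapiens), read by MTT assay, with a stated time of 72 h (a lower number here means a stronger inhibitor, a higher number a weaker inhibitor), compound 1 gives > 20000 nM
compound 2, `COc1ncnc2c1c(-c1cccs1)cn2[C@@H]1O[C@H](CO)[C@@H](O)[C@H]1O`: in this assay compound 2 gives 4850 nM

The value for compound 1 is a limit of this assay, not a number; it sits at the limit of > 20000 nM in this assay, at which 1 of the 2 values shown sits. Compound 2 therefore carries the only actual number shown. Among the measured compounds shown here, the two compounds differ in more than one place, so together they show only that compound 2 gives a measurable value where compound 1 does not.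

Compound 3, `CN(C)c1ncnc2c1c(-c1cccs1)cn2[C@@H]1O[C@H](CO)[C@@H](O)[C@H]1O`, is not yet measured. It differs from compound 2 by dimethylamino in place of methoxy on an aromatic carbon. The step of a 3.1-fold higher number from compound 2 to compound 3 (0.49 log units; beyond the scatter) is expected to weaken inhibition beyond the usual scatter. This expectation rests on compound 1, which carries the same dimethylamino group and reaches only the limit > 20000 nM. Compound 3 is thus estimated at about 15000 nM, within a range of 5000 nM to 40000 nM.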

Compound 3, half-maximal inhibitory concentration: > 20000 nM
Compound 3: a limit, no number; the forecaster's own chance of this, stated with the estimate: 45%; middle value at least 1.3-fold (0.12 log units) from the limit.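

In this assay, putting dimethylamino in place of methoxy on this aromatic carbon, with the rest of the molecule unchanged, gives an at least 4.1-fold higher number from compound 2 to compound 3 (0.61 log units; beyond the scatter). Among the compounds shown here, this is the first comparison here that differs in only one place, so the loss of a measurable value can now be tied to this change alone, without the position of the thiophene attachment also differing. Compound 3 gives a limit of the assay and not a number, so the step shows only a minimum size.

From the compounds shown here alone, whether thiophen-2-yl and thiophen-3-yl differ at all stays open, and the step between compound 1 and compound 3 cannot be read, because both compounds stand at the same limit: the limit of > 20000 nM in this assay, at which 2 of the 3 values shown sit. Also open, going by these compounds, is how a plain amino group, methylamino or a longer ether such as ethoxy would behave on this carbon.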